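The source may hold more compounds than are shown below. What is called first, only, known or untested is meant among the compounds shown, and "the series" means these compounds.

Compound 1 `CC(=O)Nc1cccc(NC(=O)COc2ccc3c(=O)ccoc3c2)c1`: 2500 nM
Compound 2 `CCCC(=O)Nc1cccc(NC(=O)COc2ccc3c(=O)ccoc3c2)c1`: 1430 nM
Compound 3 `COc1ccc(C(=O)Nc2cccc(NC(=O)COc3ccc4c(=O)ccoc4c3)c2)cc1`: 18 nM

Of the compounds shown here, three have been measured in an assay on isolated protein for inhibition of Rho-associated protein kinase 1 (Homo sapiens), read by scintillation counting, radiometric assay and 33P incorporation, with a stated time of 40 min, in the presence of a further agent that is not named here; a higher number here means a weaker inhibitor, a lower number a stronger inhibitor. Compound 3 gives the lowest number of the three: the step of a 140-fold lower number from compound 1 to compound 3 (2.14 log units; beyond the scatter) and the step of a 79-fold lower number from compound 2 to compound 3 (1.90 log units; beyond the scatter) are both large, while a 1.7-fold lower number from compound 1 to compound 2 (0.24 log units; within the scatter) stays within the scatter. Compound 4 `COC(=O)c1ccc(C(=O)Nc2cccc(NC(=O)COc3ccc4c(=O)ccoc4c3)c2)cc1` keeps everything of compound 3 except one group: methoxycarbonyl in place of methoxy on an aromatic carbon. For the measured compounds named here, none of the measured steps touches this group; the two large steps exchange a short chain on the carbonyl carbon for the whole 4-methoxyphenyl group, so they show the gain from that group as a whole and do not separate out what the methoxy alone adds. Going by the values given here, the expectation for compound 4 rests on that: the aromatic ring stays in place, so a step of about a 1.9-fold higher number from compound 3 to compound 4 (0.29 log units; within the scatter) is estimated, leaning slightly toward a higher number, with no measured step to sharpen it. In this assay compound 4 is expected to give about 35 nM, within a range from 10 nM to 150 nM.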

Compound 4, half-maximal inhibitory concentration: 72 nM
For compound 4 the middle estimate is 2.1-fold (0.31 log units) below the measured one, within the range that was stated.
By their numbers in this assay, from the lowest: compound 3; then compound 4; then compounds 2 and 1 (each within the scatter of the next).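

In this assay, for the compounds shown here, the group held at this position on the aromatic ring does matter: exchanging methoxy for methoxycarbonyl gives a 4.0-fold higher number from compound 3 to compound 4 (0.60 log units; beyond the scatter) and is the first measured change made at this spot. The gain over the short chains largely survives that exchange, with a 20-fold lower number from compound 2 to compound 4 (1.30 log units; beyond the scatter) and a 35-fold lower number from compound 1 to compound 4 (1.54 log units; beyond the scatter) both still large, so it does not depend on the methoxy group alone. Nothing available here accounts for the gap between methoxy and methoxycarbonyl.

The compounds shown leave open how a plain phenyl ring, with only hydrogen at this position, would compare, and so whether methoxy adds anything over no group at all. They also leave open how a carboxylic acid or an amine would fare at this position.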